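The source may hold more compounds than are shown below. What is called first, only, known or untested is meant among the compounds shown, and "the series" means these compounds.

Measured so far:
compound 1, `N=C(N)c1ccc(Oc2ccc(NS(=O)(=O)c3ccc(F)cc3)c(Oc3ccc(C(=N)N)cc3)n2)cc1`: 200 nM
compound 2, `N=C(N)c1ccc(Oc2ccc(NS(=O)(=O)c3cccc4cccnc34)c(Oc3ccc(C(=N)N)cc3)n2)cc1`: 200 nM

In an assay for inhibition of Suppressor of tumorigenicity 14 protein (Homo sapiens), read by fluorescence (a higher number here means a weaker inhibitor, a lower number a stronger inhibitor), compound 1 gives 200 nM and stands level with compound 2, which gives 200 nM. For the measured compounds named here, the one measured step, no change at the digits printed from compound 1 to compound 2 (within the scatter), leaves the reading unchanged within the scatter. Compound 3, `N=C(N)c1ccc(Oc2ccc(C(=O)N[C@H]3CC[C@H](N)CC3)c(Oc3ccc(C(=N)N)cc3)n2)cc1`, arises from compound 1 by (4-aminocyclohexyl)carbamoyl in place of ((4-fluorophenyl)sulfonyl)amino on an aromatic carbon. Going by the values given here, no measured step bears on this exchange: the step from compound 1 to compound 2 only swaps the group on the sulfonyl sulfur, so it gives no guide. The expected step, a 2.0-fold lower number from compound 1 to compound 3 (0.30 log units; within the scatter), therefore rests on little. Compound 3 is expected near 100 nM, with a range from 15 nM to 1000 nM.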

Compound 3, inhibition constant: 500 nM
The estimate for compound 3 lay 5.0-fold (0.70 log units) below the measured number; the measured number falls inside the stated range.
By their numbers in this assay, from the lowest: compounds 1 and 2 (each within the scatter of the next); then compound 3.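

Where compound 2 changed only the group on the sulfonyl sulfur, compound 3 replaces the whole ((4-fluorophenyl)sulfonyl)amino group on this aromatic carbon with (4-aminocyclohexyl)carbamoyl. In this assay, this exchange gives a 2.5-fold higher number from compound 1 to compound 3 (0.40 log units; beyond the scatter), a modest loss, so the sulfonyl group and the aromatic ring are not both essential for inhibition at this level. Nothing available explains the size of this step. The compounds shown leave open whether the loss follows the carbamoyl link, the cyclohexyl ring or its amine. A phenylcarbamoyl group or a plain cyclohexylcarbamoyl group at this position would separate these parts.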